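From 4-methylpiperidin-1-yl to 4-(piperidin-1-yl)piperidin-1-yl

A few compounds are considered here, and "the series" means these few. Any claim that something is new, unique, unknown or untested is made for them only; others in the source may bear on it.

Measured in a functional assay on SH-SY5Y cells (Homo sapiens) for antiproliferative activity, read by MTT assay, with a stated time of 72 h (a higher number here means a weaker inhibitor, a lower number a stronger inhibitor), so far:
compound 1 `COc1cc2c(Nc3ccc(C#N)cc3)ncnc2cc1OCCCN1CCCC1` with 8080 nM
compound 2 `COc1cc2c(Nc3ccc(C#N)cc3)ncnc2cc1OCCCN1CCC(C)CC1` with 7900 nM
compound 3 `COc1cc2c(Nc3ccc(C#N)cc3)ncnc2cc1OCCCN1CCC(N(C)C)CC1` with 24300 nM

Compound 2 (7900 nM) stands level with compound 1 at the low end of these numbers, the step between them being a 1.0-fold lower number from compound 1 to compound 2 (0.01 log units; within the scatter) and so no real separation. Compound 4 `COc1cc2c(Nc3ccc(C#N)cc3)ncnc2cc1OCCCN1CCC(N2CCCCC2)CC1` alters compound 2 at one place: piperidin-1-yl in place of methyl on a saturated ring carbon. Piperidin-1-yl thus takes the place of methyl on a saturated ring carbon.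

The closest measured precedent is the dimethylamino replacement at that same place, a 3.1-fold higher number from compound 2 to compound 3 (0.49 log units; beyond the scatter) and a modest change. The step of a 3.0-fold higher number from compound 1 to compound 3 (0.48 log units; beyond the scatter) is of similar size. Among the measured compounds shown here, only compound 3 carries such a replacement, and no measured compound has piperidin-1-yl there. A modest step towards a higher number is therefore expected in this assay, possibly a little smaller than that of compound 3. The expected change is a 2.3-fold higher number from compound 2 to compound 4 (0.36 log units; beyond the scatter). For compound 4 the estimate is 18000 nM (expected range 7500 nM to 42000 nM).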

Compound 4, half-maximal inhibitory concentration: 9810 nM
Compound 4: the middle estimate sits 1.8-fold (0.26 log units) above what was measured; the range from low to high includes it.
By their numbers in this assay, from the lowest: compounds 2, 1 and 4 (each within the scatter of the next); then compound 3.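

In this assay, a large nitrogen-bearing ring on this saturated ring carbon does not bring the shift seen with dimethylamino: piperidin-1-yl in place of methyl gives a 1.2-fold higher number from compound 2 to compound 4 (0.09 log units; within the scatter) and so leaves compound 4 level with compound 2. Compound 4 is also level with the pyrrolidin-1-yl compound, with a 1.2-fold higher number from compound 1 to compound 4 (0.08 log units; within the scatter) as the step, whereas piperidin-1-yl in place of dimethylamino gives a 2.5-fold lower number from compound 3 to compound 4 (0.39 log units; beyond the scatter), so among these four compounds only compound 3 stands apart, and a nitrogen at this place does not by itself set the outcome. Nothing available explains why these two nitrogen-bearing groups differ.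

As far as these compounds go, whether morpholin-4-yl or a hydroxyl group on the same ring carbon would stay level with methyl remains open. So does whether piperidin-1-yl would behave alike on a longer chain.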